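The source may hold more compounds than are shown below. What is called first, only, known or untested is meant among the compounds shown, and "the series" means these compounds.

Among the measured compounds shown here, in an assay on FRT-Jurkat cells for inhibition of nuclear factor NF-kappa-B complex (Homo sapiens), read by flow cytometry, with a stated time of 24 h, tested at 10 uM (a lower number here means less inhibition, a higher number more inhibition at the concentration tested (going by the name of the read-out)), compound 1 `Cc1ccccc1Nc1ccc2c(c1)C(=O)N(C1CCC(=O)NC1=O)C2=O` gives 2%, the lowest of the three numbers measured so far. Compound 2 `CC(C)(C)c1ccc(Nc2ccc3c(c2)C(=O)N(C2CCC(=O)NC2=O)C3=O)cc1` gives 17% and compound 3 `CC(C)c1ccc(Nc2ccc3c(c2)C(=O)N(C2CCC(=O)NC2=O)C3=O)cc1` gives 11%. Compound 4 `CN(c1ccccc1)c1ccc2c(c1)C(=O)N(C1CCC(=O)NC1=O)C2=O` has not yet been measured; it differs from compound 1 in that (methyl(phenyl)amino in place of (2-methylphenyl)amino on an aromatic carbon). The two measured steps from compound 1 changed the aromatic part of the group on that nitrogen but kept its hydrogen: a number 15 percentage points higher from compound 1 to compound 2 (beyond the scatter) and a number 9 percentage points higher from compound 1 to compound 3 (within the scatter). For the measured compounds named here, neither step touched the hydrogen on the nitrogen, so no measured step bears directly on the change to compound 4. With compound 1 already near the bottom of the scale, the expected step is a number 3 percentage points higher from compound 1 to compound 4 (within the scatter), within the scatter. Compound 4 is therefore estimated at 5%, with a range from -5% to 20%.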

Compound 4, a percentage reported as inhibition, at one concentration (the size of the read-out at that concentration, not a potency): -2%
For compound 4 the middle estimate is 7 percentage points above the measured one; low and high end bracket the measured number.
By their numbers in this assay, from the lowest: compounds 4, 1, 3 and 2 (each within the scatter of the next, the first and the last beyond it).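

In this assay, shifting the methyl from the aromatic ring onto the nitrogen removes the hydrogen-bond donor of the (2-methylphenyl)amino group and gives a number 4 percentage points lower from compound 1 to compound 4 (within the scatter). So losing the hydrogen on this nitrogen makes no readable difference here, although compound 1 starts so low that a further drop would be hard to see. Nothing measured on these compounds offers an explanation for this result.

Going by these compounds, whether the same change would matter with the 4-(tert-butyl)phenyl group of compound 2 remains open. So does the effect of an ethyl group on this nitrogen, or a carboxylic acid on its phenyl ring.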